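Acetyl capping of the aminopyridine in a pyrrolidine-linked series

A few compounds are considered here, and "the series" means these few. Any claim that something is new, unique, unknown or untested is made for them only; others in the source may bear on it.

Measured compounds:
compound 1 `C[C@H](NC(=O)c1ccc(-c2ccc(N)nc2)cc1)C(=O)Nc1ccc(Cl)c(C(F)(F)F)c1`: 5950 nM
compound 2 `C[C@H](NC(=O)c1cccc(-c2ccc(NS(C)(=O)=O)nc2)c1)C(=O)Nc1ccc(Cl)c(C(F)(F)F)c1`: 4660 nM
compound 3 `Nc1ccc(-c2cccc(C(=O)N[C@H]3CN[C@@H](C(=O)Nc4ccc(Cl)c(C(F)(F)F)c4)C3)c2)cn1`: 20000 nM

Of the three compounds measured in a functional assay on K562 cells (Homo sapiens) for inhibition, read by MTT assay, with a stated time of 48 h (a higher number here means a weaker inhibitor, a lower number a stronger inhibitor), compound 3 gives the highest number, at 20000 nM, and its gap to both compound 1 and compound 2 is beyond the scatter. Compound 4 `CC(=O)Nc1ccc(-c2cccc(C(=O)N[C@H]3CN[C@@H](C(=O)Nc4ccc(Cl)c(C(F)(F)F)c4)C3)c2)cn1` differs from compound 3 in one place: acetyl in place of hydrogen on a nitrogen on an aromatic ring. Among the measured compounds shown here, no step between measured compounds isolates this change, so the direction is uncertain. Compound 1 and compound 2 differ in more than one place, and their values show only that an amino and a methanesulfonamido-bearing analogue lie close together. A small step, within or near the scatter, is therefore expected, a 1.3-fold lower number from compound 3 to compound 4 (0.12 log units; within the scatter). Compound 4 is expected to give about 15000 nM, between 5000 nM and 40000 nM.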

Compound 4, half-maximal inhibitory concentration: 8710 nM
Estimate against measurement, compound 4: 1.7-fold (0.24 log units) above; measured number inside the range.
By their numbers in this assay, from the lowest: compounds 2, 1 and 4 (each within the scatter of the next); then compound 3.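

In this assay, among the compounds shown here, turning 6-aminopyridin-3-yl into 6-acetamidopyridin-3-yl gives a 2.3-fold lower number from compound 3 to compound 4 (0.36 log units; beyond the scatter) and this is the only step here that isolates a change at this nitrogen. It shows that, on the core of compound 3, a free amino group is not required for the inhibition read here and that acetyl on this nitrogen is tolerated, with a modest gain. No measurement at hand gives a reason for this shift. Going by these compounds, whether a longer acyl chain such as propanoyl or a benzoyl group on the same nitrogen would lower the number further remains open.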